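The source may hold more compounds than are shown below. What is called first, only, known or untested is meant among the compounds shown, and "the series" means these compounds.

Among the measured compounds shown here, in a functional assay, read by spectrophotometry, with a stated time of 6 min (on this read-out lower numbers stand for stronger inhibition and higher numbers for weaker inhibition), compound 1 (`CCCCCCOc1cc(OC)c(Br)cc1C(C)=O`) gives 35700000 nM, the higher of the two numbers so far, and compound 2 (`CCCCCCCCCCCCCCOc1cc(OC)c(Br)cc1C(C)=O`) gives 8700000 nM. Compound 3 (`CCCCCCOc1cc(OC)ccc1C(C)=O`) has hydrogen in place of bromo on an aromatic carbon. For the measured compounds named here, the only measured step, a 4.1-fold lower number from compound 1 to compound 2 (0.61 log units; beyond the scatter), is modest and concerns the saturated chain, so it bears only indirectly on this change. Going by the values given here, no measured step covers loss of the bromo group, so no step beyond the scatter is expected in this assay, and no direction is favoured. The expected step is a 1.1-fold higher number from compound 1 to compound 3 (0.05 log units; within the scatter). Compound 3 is estimated at 40000000 nM, within a range of 12000000 nM to 130000000 nM.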

Compound 3, half-maximal inhibitory concentration: 42100000 nM
For compound 3 the middle estimate is 1.1-fold (0.02 log units) below the measured one; measured number inside the range.
By their numbers in this assay, from the lowest: compound 2; then compounds 1 and 3 (each within the scatter of the next).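

In this assay, hydrogen in place of bromo on the aromatic carbon ortho to a methoxy group gives a 1.2-fold higher number from compound 1 to compound 3 (0.07 log units; within the scatter). Among the compounds shown here, on the core of compound 1, then, the bromo group at this position makes no difference beyond the scatter, and this is the first reading of that position. Nothing at hand offers an explanation for this result.

On these data alone, whether an amine, a carboxylic acid or a chloro group on this carbon would shift the number remains open. Also open, as far as these compounds go, is whether the longer chain of compound 2 gives a similar step on the core of compound 3.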